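The compounds below may be only part of what the source reports. "The series", "measured", "known", "first", "only" and "open" are said of these compounds alone.

Compound 3, `CCC(C)(C)Cc1c[nH]c(CCc2ccc(-c3ccccc3OCc3nc(N)n[nH]3)cc2)n1`, is the only one of this set with a number: in a functional assay for agonist activity at Bombesin receptor subtype-3 (Mus musculus) (a higher number here means that more compound is needed for the effect, a lower number that less compound is needed), compound 3 gives 4.6 nM. Among the measured compounds shown here, compound 1, `CCC(C)(C)Cc1c[nH]c(CCc2ccc(-c3ccccc3OCC(=O)O)cc2)n1`, carries the same core, and in this assay compound 1 gives "not determined" (no result reported); compound 2, `CCC(C)(C)Cc1c[nH]c(CCc2ccc(-c3ccccc3OCc3ncn[nH]3)cc2)n1`, also carries the same core, and in this assay compound 2 gives "not determined" (no result reported), so no step among measured compounds can be drawn. Compound 4, `CCC(C)(C)Cc1c[nH]c(CCc2ccc(-c3ccccc3OCc3nc(C(F)(F)F)n[nH]3)cc2)n1`, differs from compound 3 in one place: trifluoromethyl in place of amino on an aromatic carbon. For the measured compounds named here, with no comparable step on record, the change is expected to cost a little potency, a step from compound 3 to compound 4 of about a 2.2-fold higher number from compound 3 to compound 4 (0.34 log units; beyond the scatter) in this assay, near the edge of the usual scatter. Compound 4 is therefore estimated at 10 nM, within 2.5 nM to 40 nM.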

Compound 4, half-maximal effective concentration: 12 nM
Estimate against measurement, compound 4: 1.2-fold (0.08 log units) below; low and high end bracket the measured number.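

In this assay, trifluoromethyl in place of amino on the aromatic carbon between two ring nitrogen atoms gives a 2.6-fold higher number from compound 3 to compound 4 (0.42 log units; beyond the scatter), a modest change. Activity at this position therefore does not depend on the amino group, and a group of 4 heavy atoms without hydrogen-bond donors is tolerated there. Nothing on record accounts for the size of this step.

Steps involving compound 1 and compound 2 cannot be read, so the effect of having no group at this position remains unknown. As far as these compounds go, how a methyl group, a hydroxyl group or a longer chain would fare there also remains open.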